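Cyclohexyl aryl ureas: shifting the methylsulfanyl group

The compounds below may be only part of what the source reports. "The series", "measured", "known", "first", "only" and "open" are said of these compounds alone.

Compound 1 `O=C(Nc1cccc(C(F)(F)F)c1)N[C@H]1CC[C@@H](Oc2ccc(F)cc2)CC1` and compound 3 `O=C(Nc1cccc(C(F)(F)F)c1)N[C@H]1CC[C@H](OCc2ccc(F)cc2)CC1` both carry a trifluoromethyl-substituted aryl urea on the shared core. In a functional assay on CRL2813 cells (Homo sapiens) for cytotoxicity, read by sulforhodamine B assay, with a stated time of 5 days (a higher number here means a weaker inhibitor, a lower number a stronger inhibitor), compound 1 gives 2600 nM and compound 3 gives 2650 nM; these two values lie within the usual scatter of each other. Compound 2 `CSc1ccc(NC(=O)N[C@H]2CC[C@H](Oc3ccc(F)cc3)CC2)cc1` carries 4-(methylsulfanyl)phenyl instead. In this assay, going by the values given here, compound 2 returns only a limit, > 20000 nM, and is the single compound at the limit of > 20000 nM in this assay, at which 1 of the 3 values shown sits. Compound 4 `CSc1cccc(NC(=O)N[C@H]2CC[C@H](Oc3ccc(F)cc3)CC2)c1` differs from compound 2 by 3-(methylsulfanyl)phenyl in place of 4-(methylsulfanyl)phenyl on an amide-type nitrogen. Among the compounds with values here, no measured pair shows this kind of move, so its size is not known from the series; the trifluoromethyl analogues merely show that measurable inhibition is reachable on this core. Compound 4 is expected near 12000 nM, within 4000 nM to 30000 nM. The expected step is an at least 1.6-fold lower number from compound 2 to compound 4 (0.22 log units; that floor lies within the scatter).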

Compound 4, half-maximal inhibitory concentration: 11100 nM
Compound 4: middle estimate off by 1.1-fold (0.03 log units), on the high side; the range from low to high includes it.
By their numbers in this assay, from the lowest: compounds 1 and 3 (each within the scatter of the next); then compound 4. At a limit, above all of these: compound 2.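

Going by these compounds alone, with 3-(methylsulfanyl)phenyl on the amide-type nitrogen, compound 4 gives 11100 nM in this assay, the first number for a methylsulfanyl-bearing aryl urea. Replacing 4-(methylsulfanyl)phenyl with this group gives an at least 1.8-fold lower number from compound 2 to compound 4 (0.25 log units; that floor lies within the scatter), so the printed floor alone does not establish a change beyond the scatter. Compound 2 stands only at a limit of the assay: the limit of > 20000 nM in this assay, at which 1 of the 4 values shown sits.

From the compounds shown here alone, the true size of the step stays open. So does the effect of a methoxy group or a nitrile in place of the methylsulfanyl group.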